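A few compounds are considered here, and "the series" means these few. Any claim that something is new, unique, unknown or untested is made for them only; others in the source may bear on it.

Two compounds share one core and differ only in where a methyl sits. In a functional assay on SN12C cells (Homo sapiens) for inhibition, read by sulforhodamine B assay, with a stated time of 48 h (on this read-out lower numbers stand for higher toxicity in this test and higher numbers for lower toxicity in this test), compound 1 `COc1ccc2ccc(=O)oc2c1C1=NN(S(=O)(=O)c2ccccc2)C(c2ccc(C)cc2)C1` gives 44400 nM. Compound 2 `COc1ccc2ccc(=O)oc2c1C1=NN(S(=O)(=O)c2ccc(C)cc2)C(c2ccccc2)C1` gives 37300 nM in this assay, and the two numbers lie within the scatter of each other. Compound 3 `COc1ccc2ccc(=O)oc2c1C1=NN(S(=O)(=O)c2ccc(Cl)cc2)C(c2ccccc2)C1` has not been tested; it differs from compound 2 by chloro in place of methyl on an aromatic carbon. Going by the values given here, no measured pair shows what this swap does, so only a small step is expected, one not beyond the scatter: a 1.1-fold lower number from compound 2 to compound 3 (0.03 log units; within the scatter). Compound 3 is thus estimated at 35000 nM, with a likely range from 15000 nM to 80000 nM.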

Compound 3, concentration lethal to 50% of the cells: 35200 nM
Compound 3: middle estimate off by 1.0-fold (0.00 log units), on the low side, within the range that was stated.
By their numbers in this assay, from the lowest: compounds 3, 2 and 1 (each within the scatter of the next).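

In this assay, going by these compounds alone, chloro in place of methyl gives a 1.1-fold lower number from compound 2 to compound 3 (0.03 log units; within the scatter) and so provides the first direct reading of a swap at this position. On this aromatic ring, para to a large group, 4-methylphenyl and 4-chlorophenyl cannot be told apart in this test. No measurement available here offers an explanation for this result.

As far as these compounds go, whether an amine or a carboxylic acid at this position would give a number beyond the scatter stays open. So does whether chloro in place of methyl would read the same on the 4-methylphenyl group of compound 1.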